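Cyclohexyl to benzyl on the amide nitrogen of the core

This account rests on a few compounds, and the source may have more. Where it says the series, first, only, none or still open, it means among the compounds named here.

Working notes on a short series sharing one core. Compound 1 `CCCCCCNC(=O)CC1CCc2cc(OC)c(OC)cc21` carries a hexyl chain on the amide-type nitrogen; in a functional assay on the whole organism (strain Wistar) for inhibition, with Rattus norvegicus as the target, read by paw edema, with stated times of 60 min and 6 h, at a dose of 100 mg/kg by the oral route (a lower number here means less inhibition, a higher number more inhibition at the dose given (going by the name of the read-out)), compound 1 gives 38.3%. Compound 2 `COc1cc2c(cc1OC)C(CC(=O)NC1CCCCC1)CC2` carries cyclohexyl in the same place, and in this assay compound 2 gives 48.2%. For the measured compounds named here, the one measured step is a number 9.9 percentage points higher from compound 1 to compound 2 (within the scatter), so the two numbers lie within the scatter of each other; compound 2 has the higher of the two numbers, its nearest neighbour being compound 1, but nothing beyond noise separates them.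

Compound 3 `COc1cc2c(cc1OC)C(CC(=O)NCc1ccccc1)CC2` is the next step from compound 2: benzyl in place of cyclohexyl on an amide-type nitrogen. Going by the values given here, the only step that bears on it is a number 9.9 percentage points higher from compound 1 to compound 2 (within the scatter), which swapped a six-membered non-aromatic ring of carbon only for a chain and moved the read-out by less than the scatter. Among the compounds with values here, no measured step involves an aromatic ring, so the expectation rests on that single comparison alone. Compound 3 is therefore expected to show no step beyond the scatter, a number 3.2 percentage points lower from compound 2 to compound 3 (within the scatter). Compound 3 is estimated at 45%, within 28% to 62%.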

Compound 3, a percentage reported as inhibition, in the whole organism at one dose (the size of the read-out at that dose, not a potency): 30.6%
The estimate for compound 3 lay 14.4 percentage points above the measured number; low and high end bracket the measured number.
By their numbers in this assay, from the lowest: compounds 3, 1 and 2 (each within the scatter of the next, the first and the last beyond it).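

In this assay, for the compounds shown here, the substituent on the amide-type nitrogen now produces a step beyond the scatter for the first time: a number 17.6 percentage points lower from compound 2 to compound 3 (beyond the scatter), a modest change on replacing a six-membered non-aromatic ring of carbon only with benzyl. Compound 1 does not separate from compound 3, with a number 7.7 percentage points lower from compound 1 to compound 3 (within the scatter), so the hexyl chain sits within the scatter of both ring-bearing compounds and only the cyclohexyl and benzyl pair is resolved. No measurement available here gives a reason for this step.

The change from cyclohexyl to benzyl alters both the ring type and how the ring is attached to the nitrogen, so these three compounds cannot show which of the two goes with the lower read-out; cyclohexylmethyl and phenyl on the same nitrogen would separate them. Also open, as far as these compounds go, is whether the result extends to phenethyl or to a benzyl ring bearing a methoxy group or a chlorine, and since every number is a single reading at one dose, none of them speaks to potency.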